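The source may hold more compounds than are shown below. What is called first, only, known or untested is meant among the compounds shown, and "the series" means these compounds.

Working notes on the cyclopentanediol acrylamide series in an ADME assay on S2 cells (Drosophila melanogaster) for cytotoxicity, read by MTT assay; a higher number here means that more compound is needed for the effect, a lower number that less compound is needed.

Compound 1 `CN(C)C(=O)/C=C/[C@H]1C[C@@H](O)[C@@H](O)C1` carries a dimethylamide. In this assay compound 1 reaches only the assay limit of > 250000 nM, so no number is available for it. Compound 2 `CNC(=O)/C=C/[C@H]1C[C@@H](O)[C@@H](O)C1` differs by hydrogen in place of methyl on an amide-type nitrogen. In this assay compound 2 likewise sits at the assay limit of > 250000 nM, again a limit and not a number. The step that the two limits leave unreadable from compound 1 to compound 2 is therefore not readable, because both ends rest on (the limit of > 250000 nM in this assay, at which 2 of the 2 values shown sit).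

Compound 3 `O=C(/C=C/[C@H]1C[C@@H](O)[C@@H](O)C1)Nc1ccncc1` is the next member, carrying (pyridin-4-yl in place of methyl on an amide-type nitrogen). For the measured compounds named here, no measured step bears on an aryl group at this position; the only measured step, from the dimethylamide to the secondary amide, is hidden by the limit. What is known is that neither measured compound shows any cytotoxic effect within the tested range.

On that basis compound 3 is expected to remain at or near the limit, with an estimated value of 300000 nM (range 100000 nM to 1000000 nM), which corresponds to an expected step that the limit leaves unreadable from compound 2 to compound 3, not beyond scatter.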

Compound 3, half-maximal effective concentration: > 200000 nM
Compound 3: a limit, no number; the forecaster's own chance of this, stated with the estimate: 75%; the middle value lies beyond the limit too.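

In this assay compound 3 gives > 200000 nM, a limit and not a number. For the compounds shown here, compound 2 also rests on a limit, so no step to compound 3 can be read. Still open, going by these compounds, is what concentration of compound 1, compound 2 or compound 3 gives the effect, and whether pyridin-4-yl on the amide-type nitrogen changes it.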